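Swapping the Amide Aryl Group for a Pyridine Ring

This account rests on a few compounds, and the source may have more. Where it says the series, first, only, none or still open, it means among the compounds named here.

Two compounds share one core and differ only in the group on the amide-type nitrogen. Compound 1 `Nc1ccc(NC(=O)c2c(O)c3cccnc3n(-c3ccccc3)c2=O)cc1` carries a 4-aminophenyl there and in a functional assay on the whole organism for inhibition, with Rattus norvegicus as the target, read by cytopathic effect and paw edema, at a dose of 100 mg/kg by the oral route (a lower number here means less inhibition, a higher number more inhibition at the dose given (going by the name of the read-out)), compound 1 gives 0%. Among the measured compounds shown here, compound 2 `COc1ccccc1NC(=O)c1c(O)c2cccnc2n(-c2ccccc2)c1=O` carries a 2-methoxyphenyl and in this assay compound 2 gives -10.1%, the lowest of the two numbers, with a number 10.1 percentage points lower from compound 1 to compound 2 (beyond the scatter) as the only measured step. Compound 3 `O=C(Nc1cccnc1)c1c(O)c2cccnc2n(-c2ccccc2)c1=O` is not yet measured; its change from compound 2 is pyridin-3-yl in place of 2-methoxyphenyl on an amide-type nitrogen. For the measured compounds named here, no measured step covers this particular swap, and the one step available concerns a different group on the same nitrogen, so it offers little direct guidance. Both measured compounds sit near zero inhibition, and compound 3 is therefore expected to stay close to that level, with a number 10.1 percentage points higher from compound 2 to compound 3 (beyond the scatter) as the estimated step. Compound 3 is estimated at 0%, between -15% and 15%.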

Compound 3, a percentage reported as inhibition, in the whole organism at one dose (the size of the read-out at that dose, not a potency): 30.8%
Estimate against measurement, compound 3: 30.8 percentage points below, and the stated range ends below it.
By their numbers in this assay, from the lowest: compound 2; then compound 1; then compound 3.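

In this assay the group on the amide-type nitrogen proves able to shift the result strongly, not just modestly as the earlier pair suggested: pyridin-3-yl in place of 2-methoxyphenyl gives a number 40.9 percentage points higher from compound 2 to compound 3 (beyond the scatter). Pyridin-3-yl in place of 4-aminophenyl points the same way, with a number 30.8 percentage points higher from compound 1 to compound 3 (beyond the scatter), so among these three compounds the only one with a hetero atom in this aromatic ring also gives the highest number. Nothing shown here explains why the number rises.

A plain phenyl group on this nitrogen would help separate the effect of the ring nitrogen from the loss of the methoxy or amino group, and pyridin-4-yl would test whether the location of the ring nitrogen matters. From the compounds shown here alone, with results at only one dose, potency also remains open.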